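Swapping the End Group on the Hydroxy Compound

A few compounds are considered here, and "the series" means these few. Any claim that something is new, unique, unknown or untested is made for them only; others in the source may bear on it.

compound 1 `c1ccc(-c2ccc(-c3ccc(-c4nc5ccccc5[nH]4)cc3)cc2)cc1` gives 39200 nM
compound 2 `FC(F)(F)c1ccc(-c2ccc(-c3ccc(-c4nc5ccccc5[nH]4)cc3)cc2)cc1` gives 41400 nM
compound 3 `Oc1cccc2[nH]c(-c3ccc(-c4ccc(-c5ccc(C(F)(F)F)cc5)cc4)cc3)nc12` gives 2310 nM

These numbers come from a functional assay on MCF7 cells (Homo sapiens) for inhibition, read by sulforhodamine B assay (a higher number here means a weaker inhibitor of growth, a lower number a stronger inhibitor of growth), and show compound 3 lowest of the three, beyond the scatter against both others. Compound 4 `Oc1cccc2[nH]c(-c3ccc(-c4ccc(-c5cccc(Cl)c5)cc4)cc3)nc12` keeps the hydroxy group but changes one group (3-chlorophenyl in place of 4-(trifluoromethyl)phenyl on an aromatic carbon). Going by the values given here, no measured step makes this exact swap. The closest evidence is the step that added trifluoromethyl (a 1.1-fold higher number from compound 1 to compound 2 (0.02 log units; within the scatter)), which suggests that this part of the molecule may matter little. The large step came with hydroxy (an 18-fold lower number from compound 2 to compound 3 (1.25 log units; beyond the scatter)), and compound 4 retains it. No step beyond the scatter is therefore expected (a 1.1-fold higher number from compound 3 to compound 4 (0.03 log units; within the scatter)). On these data alone, the estimate for compound 4 is 2500 nM with an expected range from 800 nM to 7500 nM (wide, since 3-chlorophenyl is untested here).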

Compound 4, concentration for 50% growth inhibition: 3420 nM
Estimate against measurement, compound 4: 1.4-fold (0.14 log units) below; measured number inside the range.
By their numbers in this assay, from the lowest: compounds 3 and 4 (each within the scatter of the next); then compounds 1 and 2 (each within the scatter of the next).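

With the hydroxy group kept, this end of the molecule tolerates a real change in this assay: 3-chlorophenyl in place of 4-(trifluoromethyl)phenyl stays within the scatter (a 1.5-fold higher number from compound 3 to compound 4 (0.17 log units; within the scatter)). The earlier step at this end was read without the hydroxy group, so compound 4 extends that picture to the more active hydroxy series. No available data bear on the reason for this result.

On these data alone, because both the group and its place on the ring differ, their separate contributions stay open. Whether an amine or a carboxylic acid on this ring would fit as well is also unknown.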